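Furan with a methyl group replaces pyridine

The source may hold more compounds than are shown below. What is called first, only, known or untested is meant among the compounds shown, and "the series" means these compounds.

Three compounds share one core and differ only in the ring on the aromatic carbon between two ring nitrogen atoms. Compound 1 `O=C(NO)c1ccc(NCc2nc(-c3ccc(Br)o3)nn2-c2ccccc2)cc1` carries a 5-bromofuran-2-yl group, compound 2 `Cc1ccc(-c2nc(CNc3ccc(C(=O)NO)cc3)n(-c3ccccc3)n2)s1` a 5-methylthiophen-2-yl group, and compound 3 `O=C(NO)c1ccc(NCc2nc(-c3ccccn3)nn2-c2ccccc2)cc1` a pyridin-2-yl group. In an assay on Sf9 cells for inhibition of protein deacetylase HDAC6 (Homo sapiens), read by fluorescence, with a stated time of 40 min, tested at 100 nM (a lower number here means less inhibition, a higher number more inhibition at the concentration tested (going by the name of the read-out)), compound 1 gives 55.8%, compound 2 gives 79.7% and compound 3 gives 58.6%. Compound 3 thus stands second highest of the three numbers, with compound 1 nearest and compound 2 furthest: the step of a number 2.8 percentage points higher from compound 1 to compound 3 (within the scatter) lies within the scatter, while the step of a number 21.1 percentage points lower from compound 2 to compound 3 (beyond the scatter) lies beyond it.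

Compound 4 `Cc1ccc(-c2nc(CNc3ccc(C(=O)NO)cc3)n(-c3ccccc3)n2)o1` is not yet measured. It differs from compound 3 in that (5-methylfuran-2-yl in place of pyridin-2-yl on an aromatic carbon). The new ring resembles that of compound 1, but carries a methyl group as the thiophene of compound 2 does. The step of a number 23.9 percentage points higher from compound 1 to compound 2 (beyond the scatter) shows that adding the methyl-bearing thiophene raised inhibition, whereas the furan of compound 1 and the pyridine of compound 3 sit within the scatter of each other. A modest rise is therefore expected, estimated as a number 9.4 percentage points higher from compound 3 to compound 4 (within the scatter) in this assay. Compound 4 is estimated at 68%, with a range from 52% to 82%.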

Compound 4, a percentage reported as inhibition, at one concentration (the size of the read-out at that concentration, not a potency): 60.7%
Estimate against measurement, compound 4: 7.3 percentage points above, within the range that was stated.
By their numbers in this assay, from the lowest: compounds 1, 3 and 4 (each within the scatter of the next); then compound 2.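

In this assay, moving to the 5-methylfuran-2-yl group gives a number 2.1 percentage points higher from compound 3 to compound 4 (within the scatter) and so does not separate this five-membered ring with one oxygen from the six-membered pyridin-2-yl ring, while methyl in place of bromo on the furan gives a number 4.9 percentage points higher from compound 1 to compound 4 (within the scatter) and leaves the two furans unseparated as well. The sharper information comes from keeping the methyl group and exchanging only the ring, which gives a number 19 percentage points lower from compound 2 to compound 4 (beyond the scatter) and shows that a methyl group on a furan does not match what the same group does on a thiophene, so among these four compounds the 5-methylthiophen-2-yl group alone stands apart at this position. No measurement in hand explains why the thiophene differs from the furan.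

The compounds shown leave open whether the thiophene would stand apart without its methyl group, since neither plain thiophen-2-yl nor 5-bromothiophen-2-yl appears among them. They also say nothing about how this position would respond to a non-aromatic group such as an aminomethyl or a longer alkyl chain, or about how these compounds behave against any other deacetylase.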